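Swapping Phenyl for Methoxymethyl on the Carbonyl Carbon

The source may report more compounds than this note shows. Statements on the series, on what has been measured and on what is new or still open speak of the compounds shown alone.

In a functional assay on KB cells (Homo sapiens) for antiproliferative activity, read by sulforhodamine B assay, with a stated time of 3 days (on this read-out lower numbers stand for stronger inhibition of growth and higher numbers for weaker inhibition of growth), compound 1 `O=C(Nc1cccc(Nc2ncc(F)c(Nc3ccc(F)cc3)n2)c1)c1cnccn1` gives 23600 nM as a measured number. Compound 2 `O=C(Nc1cccc(Nc2ncc(F)c(Nc3ccc(F)cc3)n2)c1)c1ccccc1` stands at > 10000 nM in this assay and this is a limit of the assay, not a number. Compound 3 `COCC(=O)Nc1cccc(Nc2ncc(F)c(Nc3ccc(F)cc3)n2)c1` differs from compound 2 by methoxymethyl in place of phenyl on a carbonyl carbon and keeps the shared core unchanged. Among the measured compounds shown here, only one measured step bears on this change, a step that the limit leaves unreadable from compound 1 to compound 2 with phenyl in place of pyrazin-2-yl on that same carbonyl carbon. It gives no size for a change at this place and no direction for the next one. For the measured compounds named here, compound 1 at 23600 nM is the only true number nearby, so weak inhibition of growth is expected to continue. The evidence so far includes the limit of > 10000 nM in this assay, at which 1 of the 2 values shown sits, and a second limit may well appear. The expected move is a step that the limit leaves unreadable from compound 2 to compound 3 with no clear direction. Compound 3 is estimated at 18000 nM with an expected range from 6000 nM to 50000 nM in this assay for now.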

Compound 3, concentration for 50% growth inhibition: 6250 nM
For compound 3 the middle estimate is 2.9-fold (0.46 log units) above the measured one; measured number inside the range.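

Among the compounds shown here, this is the first step at this position with a readable size: in this assay, replacing pyrazin-2-yl with methoxymethyl on the carbonyl carbon gives a 3.8-fold lower number from compound 1 to compound 3 (0.58 log units; beyond the scatter). The position therefore accepts an open chain with no ring, and among the compounds shown that chain gives the lowest number, though the comparison with the phenyl compound is less firm, with only an at least 1.6-fold lower number from compound 2 to compound 3 (0.20 log units; that floor lies within the scatter). That figure is a floor and the true step could be larger, as compound 2 has a limit of the assay rather than a number: the limit of > 10000 nM in this assay, at which 1 of the 3 values shown sits.

The compounds shown cannot tell whether the lower number goes with the ether oxygen of methoxymethyl or simply with the absence of a ring, and a plain ethyl group on the same carbonyl carbon would help to separate the two. On these data alone, how far the trend extends also remains open, for example to a longer chain such as methoxyethyl or to an amine such as dimethylaminomethyl.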